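The source may report more compounds than this note shows. Statements on the series, on what has been measured and on what is new or still open speak of the compounds shown alone.

In a functional assay on HT-1080 cells (Homo sapiens) for antiproliferative activity, read by MTT assay, with a stated time of 72 h (on this read-out lower numbers stand for stronger inhibition and higher numbers for weaker inhibition), compound 3 `COc1ccc(-c2cc(C(=O)O)sc2-c2cc(OC)c(OC)c(OC)c2)cc1` gives 5810 nM, and compound 2 `CCOC(=O)c1cc(-c2ccc(OC)cc2)c(-c2cc(OC)c(OC)c(OC)c2)s1` gives 7630 nM. Among the measured compounds shown here, these two values lie within the scatter of each other: the one measured step between them, hydrogen in place of ethyl, is a 1.3-fold lower number from compound 2 to compound 3 (0.12 log units; within the scatter). The next compound, compound 4 `COc1ccc(-c2cc(C(=O)O)sc2-c2cc(OC)c(OC)c(OC)c2)cc1OCc1ccccc1`, keeps everything in compound 3 except for one change: benzyloxy in place of hydrogen on an aromatic carbon. A benzyloxy group replaces hydrogen on an aromatic carbon, ortho to a methoxy group and meta to a large group.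

For the measured compounds named here, no measured step tests this change directly, since the step to compound 3 took place elsewhere in the molecule. Its small size, a 1.3-fold lower number from compound 2 to compound 3 (0.12 log units; within the scatter), therefore says little about the new group. The only other hint comes from compound 1 `COc1ccc(-c2sccc2-c2cc(OC)c(OC)c(OC)c2)cc1OCc1ccccc1`, which also carries benzyloxy. In this assay, compound 1 reads > 100000 nM, which is a limit of the assay and not a number. Compound 1 differs from compound 3 in more than one place, so this hint is loose, though it points towards weaker inhibition. The expected change is therefore a moderate rise, a 2.6-fold higher number from compound 3 to compound 4 (0.41 log units; beyond the scatter), with much uncertainty. For compound 4 the estimated value is 15000 nM, with an expected range from 4000 nM to 80000 nM.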

Compound 4, half-maximal inhibitory concentration: > 100000 nM
Compound 4 gave a limit, no number; the forecaster's own chance of this, stated with the estimate: 20%; middle value at least 6.6-fold (0.82 log units) from the limit.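

Among the compounds shown here, the pair of compound 3 and compound 4 is the first direct test of this position, and in this assay it shows that benzyloxy in place of hydrogen on an aromatic carbon, ortho to a methoxy group and meta to a large group, is far from a neutral change: the step is an at least 17-fold higher number from compound 3 to compound 4 (1.23 log units; beyond the scatter). For the compounds shown here, until now benzyloxy had been seen only in compound 1, which differs from compound 3 in more than one place, so weak inhibition could not be tied to this group; compound 4 differs from compound 3 in this one place alone. Compound 4 gives > 100000 nM, which is a limit of the assay and not a number, and it is not alone there: the limit of > 100000 nM in this assay, at which 2 of the 4 values shown sit.

As far as these compounds go, whether a smaller group at this place, such as ethoxy or a hydroxyl group, would keep the inhibition seen with compound 3 remains open. Also open is how an amine at this place would read, and with no number for any benzyloxy compound shown, changes elsewhere in the molecule cannot be judged alongside this group.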